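Replacing a Furan with a Tolyl Group: Expected Cytotoxicity

The compounds below may be only part of what the source reports. "The series", "measured", "known", "first", "only" and "open" are said of these compounds alone.

The measured compounds:
compound 1 `Cc1cc(C#N)cc(C)c1Oc1nc(Nc2ccc(C#N)cc2)ncc1-c1ccncc1`, 28000 nM;
compound 2 `Cc1cc(C#N)cc(C)c1Oc1nc(Nc2ccc(C#N)cc2)ncc1-c1cccc2ccccc12`, > 267000 nM;
compound 3 `Cc1cc(C#N)cc(C)c1Oc1nc(Nc2ccc(C#N)cc2)ncc1-c1ccco1`, > 306000 nM.

In an ADME assay on MT4 cells (Homo sapiens) for cytotoxicity, read by MTT assay, with a stated time of 5 days (a lower number here means that less compound is tolerated, a higher number that more compound is tolerated), compound 1 gives 28000 nM. Compound 2 reaches only a limit of this assay, > 267000 nM. Compound 3 likewise reaches only a limit of this assay, > 306000 nM, so compound 3 stands at the upper edge of what the numbers shown can tell. Going by the values given here, compound 4 `Cc1ccc(-c2cnc(Nc3ccc(C#N)cc3)nc2Oc2c(C)cc(C#N)cc2C)cc1` has not been measured. 4-methylphenyl in place of furan-2-yl on an aromatic carbon The steps that bear on this are an at least 9.5-fold higher number from compound 1 to compound 2 (0.97 log units; beyond the scatter) and an at least 10-fold higher number from compound 1 to compound 3 (1.03 log units; beyond the scatter); both carbocyclic or oxygen-containing replacements of pyridin-4-yl ended at a limit of > 267000 nM in this assay, at which 1 of the 3 values shown sits (the limit of > 306000 nM in this assay, at which 1 of the 3 values shown sits). The step that the two limits leave unreadable from compound 2 to compound 3 cannot be read. Compound 4 is therefore expected to show no step beyond the scatter, an at least 1.0-fold lower number from compound 3 to compound 4 (0.00 log units; that floor lies within the scatter). Compound 4 is estimated at 300000 nM, between 100000 nM and 700000 nM.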

Compound 4, half-maximal cytotoxic concentration: 26100 nM
Compound 4: the middle estimate sits 11-fold (1.06 log units) above what was measured; the whole stated range lies above it.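

Putting 4-methylphenyl at this position gives an at least 11-fold lower number from compound 3 to compound 4 (1.06 log units; beyond the scatter) in this assay and, against naphthalen-1-yl, an at least 10-fold lower number from compound 2 to compound 4 (1.00 log units; beyond the scatter) in the same assay. Against pyridin-4-yl it gives a 1.1-fold lower number from compound 1 to compound 4 (0.03 log units; within the scatter) in that assay, so a limit is not what every replacement of pyridin-4-yl reaches. Rings of carbon only thus fall on both sides, with compound 2 at a limit and compound 4 not.

From the compounds shown here alone, whether the methyl of 4-methylphenyl matters remains open, and a plain phenyl group would address it. Nothing shown accounts for these steps.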